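The source may report more compounds than this note shows. Statements on the series, on what has been measured and on what is new or still open speak of the compounds shown alone.

Measured in a functional assay on MCF7 cells (Homo sapiens) for cytotoxicity; a lower number here means a stronger inhibitor, a higher number a weaker inhibitor:
- compound 1 `CCC(CO)Nc1nc(NCc2ccccc2)c2nc(Cl)n(C(C)C)c2n1`: 54000 nM
- compound 2 `CCC(CO)Nc1nc(NCc2ccccc2)c2nc(N)n(C(C)C)c2n1`: 60000 nM
- compound 3 `CCC(CO)Nc1nc(NCc2ccccc2)c2nc([N+](=O)[O-])n(C(C)C)c2n1`: 117000 nM

These three compounds share one core and differ only in a single group on an aromatic carbon, between two ring nitrogen atoms. Compound 3, the nitro member, has a number of 117000 nM in this assay. Putting nitro in place of chloro gives a 2.2-fold higher number from compound 1 to compound 3 (0.34 log units; beyond the scatter). Putting nitro in place of amino gives a 2.0-fold higher number from compound 2 to compound 3 (0.29 log units; within the scatter), so those two values cannot be told apart.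

The next compound, compound 4 `CCC(CO)Nc1nc(NCc2ccccc2)c2nc(NCCCO)n(C(C)C)c2n1`, has (3-hydroxypropyl)amino in place of nitro on that same carbon: (3-hydroxypropyl)amino in place of nitro on an aromatic carbon. Within the data shown here, no measured compound carries a chain at this position, so the evidence is indirect. The closest measured group is the amino of compound 2, which stands at 60000 nM. Swapping chloro for amino changed little, with a 1.1-fold higher number from compound 1 to compound 2 (0.05 log units; within the scatter).

Compound 4 is therefore expected to fall near compound 2, and only a small step is foreseen in this assay, towards a lower number. The estimated change is a 2.0-fold lower number from compound 3 to compound 4 (0.29 log units; within the scatter). For compound 4 the expected value is 60000 nM, with an estimated range from 25000 nM to 130000 nM.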

Compound 4, half-maximal inhibitory concentration: 40000 nM
Estimate against measurement, compound 4: 1.5-fold (0.18 log units) above; low and high end bracket the measured number.
By their numbers in this assay, from the lowest: compounds 4, 1, 2 and 3 (each within the scatter of the next, the first and the last beyond it).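

The carbon between two ring nitrogen atoms can carry a chain without the number in this assay leaving the range of the smaller groups, and replacing nitro with (3-hydroxypropyl)amino gives a small but real change (a 2.9-fold lower number from compound 3 to compound 4 (0.47 log units; beyond the scatter)). Adding 3-hydroxypropyl to the nitrogen of the amino group makes no difference that can be told apart (a 1.5-fold lower number from compound 2 to compound 4 (0.18 log units; within the scatter)), and neither does replacing chloro with the whole chain (a 1.4-fold lower number from compound 1 to compound 4 (0.13 log units; within the scatter)). Nitro is therefore the only group here that stands apart from any other, and only from chloro and (3-hydroxypropyl)amino, since its gap to amino stays within the scatter.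

Going by these compounds, it remains open whether a shorter or longer chain on that nitrogen, a propyl chain without the hydroxyl, or a ring amine such as morpholine would shift the number any further than these groups do. Nothing available here explains these steps or shows what lies behind the difference between nitro and the chain.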